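This account rests on a few compounds, and the source may have more. Where it says the series, first, only, none or still open, it means among the compounds named here.

Measured in a functional assay on HCT-116 cells (Homo sapiens) for antiproliferative activity, read by MTT assay, with a stated time of 72 h; a higher number here means a weaker inhibitor, a lower number a stronger inhibitor:

Compound 1 `C=C1CN/C(=N/c2ccccc2)S1`: > 100000 nM
Compound 2 `COc1ccc(/C=C2/CN(C)/C(=N/c3ccc(Cl)cc3)S2)cc1`: 9800 nM
Compound 3 `COc1ccc(/C=C2\S/C(=N\c3ccc(Cl)cc3)N(C)C2=O)cc1`: 10400 nM

The value given for compound 1 is a limit of this assay, not a number (the limit of > 100000 nM in this assay, at which 1 of the 3 values shown sits). Among the two numbers, compound 3 has the higher one, but its number lies within the scatter of that of compound 2, so no order between them can be read. The next compound, compound 4 `COc1ccc(/C=C2\S/C(=N\c3ccc(Br)cc3)N(C)C2=O)cc1`, differs from compound 3 in one place: bromo in place of chloro on an aromatic carbon. For this change in this assay the account expects no step beyond the scatter, a 1.1-fold lower number from compound 3 to compound 4 (0.04 log units; within the scatter), so compound 4 is estimated at 9500 nM, within 4000 nM to 22000 nM.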

Compound 4, half-maximal inhibitory concentration: 17000 nM
Estimate against measurement, compound 4: 1.8-fold (0.25 log units) below, within the range that was stated.
By their numbers in this assay, from the lowest: compounds 2, 3 and 4 (each within the scatter of the next). At a limit, above all of these: compound 1.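

In this assay, the swap at this place on the aromatic ring gives a 1.6-fold higher number from compound 3 to compound 4 (0.21 log units; within the scatter), so this exchange of one halogen for another, para to a large group, separates the two compounds by no more than the scatter. Nothing in the data shown gives a cause for this step.

Going by these compounds, it remains open whether an amine, a carboxylic acid or a plain hydrogen in place of the halogen would give a number apart from these. On these data alone, it is also open whether bromo in place of chloro would behave the same way on the core of compound 2.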